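This account rests on a few compounds, and the source may have more. Where it says the series, first, only, none or still open, it means among the compounds named here.

Among the compounds with values here, compound 3 `NC(=O)c1c(NC(=O)c2ccccc2Br)sc2c1CCN(C(=S)Nc1ccccc1Br)C2` gives the only number in the set for a functional assay on HeLa cells (Homo sapiens) for antiproliferative activity, with a stated time of 24 h (on this read-out lower numbers stand for stronger inhibition and higher numbers for weaker inhibition), at 24700 nM. Compound 1 `Cc1ccccc1NC(=S)N1CCc2c(sc(NC(=O)c3ccccc3Cl)c2C(N)=O)C1` sits at a limit of this assay, > 50000 nM. Compound 2 `NC(=O)c1c(NC(=O)c2ccccc2Br)sc2c1CCN(C(=S)Nc1ccccc1F)C2` likewise sits at a limit, > 50000 nM. Within the data shown here, the single measured step in this assay, an at least 2.0-fold lower number from compound 2 to compound 3 (0.30 log units; that floor lies within the scatter), is bromo in place of fluoro on an aromatic carbon; its floor lies within the scatter, so its true size is not fixed.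

Compound 4 `Cc1ccccc1NC(=S)N1CCc2c(sc(NC(=O)c3ccccc3Br)c2C(N)=O)C1` is the next member; relative to compound 3 the change is methyl in place of bromo on an aromatic carbon. Among the measured compounds shown here, this runs away from the bromo that accompanies the only numbered value, and toward the 2-methylphenyl group that compound 1 also carries, while compound 1 sits at the limit of > 50000 nM in this assay, at which 2 of the 3 values shown sit. The step from compound 3 to compound 4 is therefore expected to move the number upward, a 2.4-fold higher number from compound 3 to compound 4 (0.39 log units; beyond the scatter), though the measured step that bears on it is itself only a floor. For compound 4 the expected value in this assay is 60000 nM, with a range from 20000 nM to 150000 nM, and a substantial chance that only a limit is returned.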

Compound 4, half-maximal inhibitory concentration: > 50000 nM
Compound 4: no number, only a limit; the forecaster's own chance of this, stated with the estimate: 65%; the middle value does not contradict the limit.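

In this assay, methyl in place of bromo on an aromatic carbon ortho to a large group gives an at least 2.0-fold higher number from compound 3 to compound 4 (0.30 log units; that floor lies within the scatter), so this change is fixed only as a floor. Compound 4 returns a limit and not a number: the limit of > 50000 nM in this assay, at which 3 of the 4 values shown sit. Across compound 2, compound 3 and compound 4, which differ only at this position, bromo is now the only one of the three groups shown that gives a number, as methyl in compound 4 and fluoro in compound 2 both end at a limit.

The steps from compound 2 and from compound 1 to compound 4 cannot be read, as both ends of each are limits, which leaves methyl against fluoro and bromo against chloro unordered. On these data alone, how an amine or a carboxylic acid at this position would read remains open.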